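Aryl ether swap carried from one core to another

The source may report more compounds than this note shows. Statements on the series, on what has been measured and on what is new or still open speak of the compounds shown alone.

Compound 1 `Cc1nc2ccccc2c(=O)n1/N=C/c1ccc(Oc2ccc3ccccc3c2)cc1` gives 5.22 in a physicochemical assay for lipophilicity, in phosphate buffer, measured as octanol-water partition; on this read-out lower numbers stand for lower lipophilicity and higher numbers for higher lipophilicity. Compound 2 `Cc1nc2ccccc2c(=O)n1/N=C/c1ccc(Oc2ccc(F)cc2)cc1` differs from it in one place, (4-fluorophenyl in place of naphthalen-2-yl on an oxygen on an aromatic ring), and in this assay compound 2 gives 4.21; the step is a number 1.01 log units lower from compound 1 to compound 2 (beyond the scatter). Compound 3 `O=c1c2ccccc2nc(-c2ccccc2)n1/N=C/c1ccc(Oc2ccc3ccccc3c2)cc1` carries a different core, the difference being (phenyl in place of methyl on an aromatic carbon), and in this assay compound 3 gives 6.53, the highest of the three measured numbers, with a number 1.31 log units higher from compound 1 to compound 3 (beyond the scatter). Compound 4 `O=c1c2ccccc2nc(-c2ccccc2)n1/N=C/c1ccc(Oc2ccc(F)cc2)cc1` is not yet measured. It stands to compound 3 as compound 2 stands to compound 1: the difference is 4-fluorophenyl in place of naphthalen-2-yl on an oxygen on an aromatic ring, at a place whose surroundings read the same as before, so it is the same change made on the other core. Within the data shown here, only one measured pair shows this change, so any transfer rests on a single step. Among the measured compounds shown here, the step from compound 3 to compound 4 in this assay is expected to be a number 1.01 log units lower from compound 3 to compound 4 (beyond the scatter), set beside a number 1.01 log units lower from compound 1 to compound 2 (beyond the scatter), because compound 3 starts from 6.53 and the change repeats the one that gave a number 1.01 log units lower from compound 1 to compound 2 (beyond the scatter). For compound 4 the expected value in this assay is 5.52, with the range from 5.1 to 5.95 expected to hold it.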

Compound 4, partition coefficient: 6.21
The estimate for compound 4 lay 0.69 log units below the measured number, outside the stated range (above it).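

In this assay the swap of naphthalen-2-yl for 4-fluorophenyl runs the same way on both cores but is smaller on the core of compound 3, with a number 0.32 log units lower from compound 3 to compound 4 (beyond the scatter) set against a number 1.01 log units lower from compound 1 to compound 2 (beyond the scatter) on the core of compound 1. The phenyl in place of methyl change agrees with this, giving a number 2.00 log units higher from compound 2 to compound 4 (beyond the scatter) where the naphthalen-2-yl pair gave a number 1.31 log units higher from compound 1 to compound 3 (beyond the scatter) and so showing that the two changes do not simply add in these four compounds; the direction of the swap carried across, its size did not, and two pairs cannot show whether either would hold on a further core. Nothing measured here explains the smaller step on the core of compound 3.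

Among these compounds, with only two groups at each of the two places, it remains open whether the smaller step belongs to the phenyl-bearing core generally or to this one swap. An amine or a carboxylic acid in place of the aryl group on the oxygen, or a longer chain in place of methyl on the aromatic carbon, would extend the comparison.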